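Para-substituent series on the triazole aryl arm

The compounds below may be only part of what the source reports. "The series", "measured", "known", "first", "only" and "open" are said of these compounds alone.

Measured so far:
compound 1 `C=C1C[C@]23C[C@@]1(O)CC[C@H]2c1ccc(O)c(C)c1[C@@H]3Cn1cc(-c2ccc(C(F)(F)F)cc2)nn1` — 12400 nM
compound 2 `C=C1C[C@]23C[C@@]1(O)CC[C@H]2c1ccc(O)c(C)c1[C@@H]3Cn1cc(-c2ccc(Br)cc2)nn1` — > 20000 nM

Compound 1 is the only one of the two with a numbered value in a functional assay on MCF7 cells (Homo sapiens) for cytotoxicity, read by MTT assay, with a stated time of 4 days; on this read-out higher numbers stand for weaker inhibition and lower numbers for stronger inhibition. For compound 2 the value in this assay is a limit of the assay, not a number; it sits at the limit of > 20000 nM in this assay, at which 1 of the 2 values shown sits, so the step of an at least 1.6-fold higher number from compound 1 to compound 2 (0.20 log units; that floor lies within the scatter) is known only as a floor. Compound 2 therefore stands at the weak end of what has been measured, with no firm figure of its own.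

Compound 3 `C=C1C[C@]23C[C@@]1(O)CC[C@H]2c1ccc(O)c(C)c1[C@@H]3Cn1cc(-c2ccccc2)nn1` has not yet been measured in this assay. It differs from compound 2 by hydrogen in place of bromo on an aromatic carbon. Going by the values given here, no measured step covers a change from a para group to phenyl. The only step shown, an at least 1.6-fold higher number from compound 1 to compound 2 (0.20 log units; that floor lies within the scatter), varies the para group and moved the number up to the limit, which gives a direction but no size. On that basis no shift beyond the scatter from compound 2 is expected for compound 3, and a limit read-out is the likelier outcome.

Estimate for compound 3: 25000 nM, range 8000 nM to 80000 nM, implying an expected step that the limit leaves unreadable from compound 2 to compound 3.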

Compound 3, half-maximal inhibitory concentration: > 20000 nM
Compound 3 was reported as a limit (the forecaster's own chance of this, stated with the estimate: 60%); the middle value lies beyond the limit too.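

In this assay the unsubstituted phenyl arm of compound 3 also gives a limit, as the 4-bromophenyl arm of compound 2 does, so hydrogen in place of bromo brings no numbered value into view and the step between these two cannot be read. Hydrogen in place of trifluoromethyl gives an at least 1.6-fold higher number from compound 1 to compound 3 (0.20 log units; that floor lies within the scatter), the same floor as the bromo change, so neither change is shown to move the number beyond the scatter. Compound 1 thus remains the only one of the three with a numbered value, and the read-out at this position is now mostly bounded by the top of the assay: the limit of > 20000 nM in this assay, at which 2 of the 3 values shown sit.

Going by these compounds alone, whether any group at this position can shift the number clearly beyond the scatter stays open, since the only readable steps are floors that lie within it. An amine, a carboxylic acid or a longer chain such as butyl on the aryl ring would show whether the series can give numbered values well away from the limit.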